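The source may hold more compounds than are shown below. What is called first, only, known or untested is meant among the compounds shown, and "the series" means these compounds.

Measured so far:
compound 1 `CC(C)N(C(=S)SCc1oc2ccccc2c(=O)c1Cl)C(C)C`; in a functional assay on LM7 cells (Homo sapiens) for antiproliferative activity, read by MTT assay, with a stated time of 72 h (a lower number here means a stronger inhibitor, a higher number a weaker inhibitor), compound 1 gives > 40000 nM, which is a limit of the assay and not a number.
compound 2 `O=c1c(Cl)c(CSC(=S)N2CCCC2)oc2ccccc12`; in this assay compound 2 gives 1900 nM.

Compound 2 holds the only number shown in this assay; the other value shown is a limit, namely (the limit of > 40000 nM in this assay, at which 1 of the 2 values shown sits). Among the compounds with values here, the single measured step, an at least 21-fold lower number from compound 1 to compound 2 (1.32 log units; beyond the scatter), is the whole of what is known about how the amine on the thiocarbonyl carbon moves the number, and it is large.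

Compound 3 `O=c1c(Cl)c(CSC(=S)N2CCOCC2)oc2ccccc12` is not yet measured in this assay. Against compound 2 the change is morpholin-4-yl in place of pyrrolidin-1-yl on a thiocarbonyl carbon. This exchanges one cyclic amine for another, a narrower change than the one measured, which moved from an open-chain diisopropylamino group to pyrrolidin-1-yl; no step between two cyclic amines is shown in the series, so the measured step sets only an upper bound on what to expect. The expectation for compound 3 is a step of a 2.1-fold higher number from compound 2 to compound 3 (0.32 log units; beyond the scatter), small and towards a higher number, not clearly beyond the scatter. Compound 3 is estimated at 4000 nM, within 1500 nM to 15000 nM.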

Compound 3, half-maximal inhibitory concentration: 19200 nM
The estimate for compound 3 lay 4.8-fold (0.68 log units) below the measured number; the whole stated range lies below it.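

In this assay the choice between two cyclic amines on the thiocarbonyl carbon proves to matter: morpholin-4-yl in place of pyrrolidin-1-yl gives a 10-fold higher number from compound 2 to compound 3 (1.00 log units; beyond the scatter) in this series, so a ring at this position does not by itself secure the lower number seen for compound 2. Morpholin-4-yl in place of diisopropylamino gives an at least 2.0-fold lower number from compound 1 to compound 3 (0.31 log units; beyond the scatter) and places compound 3 on the lower side of the open-chain amine, though much of the gain seen with pyrrolidin-1-yl is absent. Compound 1 stands at a limit of the assay and not at a number, so its steps have no known upper size: the limit of > 40000 nM in this assay, at which 1 of the 3 values shown sits.

The step to morpholin-4-yl changes ring size and adds a ring oxygen together, and the compounds shown do not tell these two changes apart. A piperidin-1-yl group on the thiocarbonyl carbon would separate them, and a diethylamino group would show whether diisopropylamino speaks for open-chain amines in general or only for itself.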